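A few compounds are considered here, and "the series" means these few. Any claim that something is new, unique, unknown or untested is made for them only; others in the source may bear on it.

Compound 1 `Cn1c(=O)c2c(nc(SCCc3ccc(Br)cc3)n2C)n(C)c1=O` has the lowest number of the three measured in an assay on microsomes for inhibition of Amine oxidase [flavin-containing] B (Homo sapiens), read by fluorescence and spectrophotometry, with a stated time of 20 min (on this read-out higher numbers stand for weaker inhibition and lower numbers for stronger inhibition), at 19 nM. Compound 2 `Cn1c(=O)c2c(nc(SCCc3ccc(F)cc3)n2C)n(C)c1=O` gives 71 nM, and compound 3 `Cn1c(=O)c2c(nc([S+]([O-])CCc3ccc(F)cc3)n2C)n(C)c1=O` gives 3500 nM. Within the data shown here, the only step that touches the change now in question is a 3.7-fold higher number from compound 1 to compound 2 (0.57 log units; beyond the scatter), a swap of one halogen for another. Among the measured compounds shown here, compound 4 `Cn1c(=O)c2c(nc(SCCCc3ccc(Cl)cc3)n2C)n(C)c1=O` differs from compound 1 by 4-chlorobenzyl in place of 4-bromophenyl on a saturated chain carbon, two bonds along the chain from a sulfur, which both swaps the halogen and lengthens the chain by one carbon; no measured pair speaks to the chain length. A modest rise in this assay is therefore expected, smaller than the fluoro step, with wide uncertainty. For compound 4 the expected value is 40 nM, between 12 nM and 130 nM, an estimated 2.1-fold higher number from compound 1 to compound 4 (0.32 log units; beyond the scatter).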

Compound 4, half-maximal inhibitory concentration in the Amine oxidase [flavin-containing] B assay: 61 nM
Estimate against measurement, compound 4: 1.5-fold (0.18 log units) below; the measured number falls inside the stated range.
By their numbers in the Amine oxidase [flavin-containing] B assay, from the lowest: compound 1; then compounds 4 and 2 (each within the scatter of the next); then compound 3.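

At this position, the 4-chlorobenzyl group weakens inhibition in the Amine oxidase [flavin-containing] B assay, with a 3.2-fold higher number from compound 1 to compound 4 (0.51 log units; beyond the scatter), while the step from the 4-fluorophenyl group reads a 1.2-fold lower number from compound 2 to compound 4 (0.07 log units; within the scatter). The longer group is therefore accepted here without a loss beyond that seen with the 4-fluorophenyl group. It also makes the compound more lipophilic in a physicochemical assay for lipophilicity, using the shake flask method, measured as octanol-water partition (a higher number here means a more lipophilic compound, a lower number a more polar compound), without stronger inhibition: the measured partition coefficient of compound 1, 2.98, and of compound 4, 3.59, a number 0.61 log units higher (beyond the scatter) In the physicochemical assay compound 1 gives 2.98 and compound 4 gives 3.59.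

The compounds shown do not separate the halogen swap from the added chain carbon. Going by these compounds, a 4-bromobenzyl group, a longer chain or an amine at this position remains open.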